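Swapping chloro for methyl on a shared core

The source may report more compounds than this note shows. Statements on the series, on what has been measured and on what is new or still open speak of the compounds shown alone.

Three close relatives of one shared core have been tested in a functional assay on C6 cells (Rattus norvegicus) for cytotoxicity, read by MTT assay, with a stated time of 24 h; on this read-out higher numbers stand for weaker inhibition and lower numbers for stronger inhibition. Compound 1 `Cc1cc(-c2nc3cc(Cl)ccc3o2)ccc1NC(=O)CN1CCN(CCN(C)C)CC1` gives 13500 nM, and compound 3 `Cc1cc(-c2nc3cc(Cl)ccc3o2)ccc1NC(=O)CN1CCN(CCCN(C)C)CC1` gives 14200 nM; the step of a 1.1-fold higher number from compound 1 to compound 3 (0.02 log units; within the scatter) changes nothing beyond the scatter. Compound 2 `Cc1cc(-c2nc3cc(F)ccc3o2)ccc1NC(=O)CCl` yields only a limit of the assay, > 100000 nM. Among the two numbers, compound 3 and compound 1 sit together within the scatter, so compound 3 stands with compound 1 as its nearest neighbour. Compound 4 `Cc1ccc2oc(-c3ccc(NC(=O)CN4CCN(CCCN(C)C)CC4)c(C)c3)nc2c1` differs from compound 3 by methyl in place of chloro on an aromatic carbon. Among the compounds with values here, no measured step touches that position, and the numbers give no guide to its effect. Compound 4 is therefore expected to stay near compound 3, with an estimated step of a 1.0-fold lower number from compound 3 to compound 4 (0.01 log units; within the scatter). The estimate for compound 4 is 14000 nM, within a range from 5000 nM to 40000 nM.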

Compound 4, half-maximal inhibitory concentration: 7320 nM
Compound 4: middle estimate off by 1.9-fold (0.28 log units), on the high side; low and high end bracket the measured number.
By their numbers in this assay, from the lowest: compounds 4, 1 and 3 (each within the scatter of the next). At a limit, above all of these: compound 2.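

Within the data shown here, this is the first measured change at this aromatic carbon of the shared core: in this assay, methyl in place of chloro gives a 1.9-fold lower number from compound 3 to compound 4 (0.29 log units; within the scatter), so on this read-out the two groups cannot be told apart at this position. Going from 5-chloro-1,3-benzoxazol-2-yl to 5-methyl-1,3-benzoxazol-2-yl thus has no effect that can be separated from the scatter. Nothing given here bears on the reason for this step.

From the compounds shown here alone, whether a larger or very different group here, such as methoxy or a carboxylic acid, would shift the number beyond the scatter remains open.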